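Aryl variation on the thioether chain: stability notes

The source may hold more compounds than are shown below. What is called first, only, known or untested is meant among the compounds shown, and "the series" means these compounds.

Measured so far in an ADME assay on microsomes from liver (Mus musculus, strain CD-1) for metabolic stability, read by LC-MS, with a stated time of 60 min, tested at 20 uM; a lower number here means that the compound disappears faster, a higher number that the compound lasts longer:
- compound 1 `CC(Sc1nc2c(cnn2C)c(=O)n1-c1ccccc1)c1ccccn1`: 0.833 h
- compound 2 `COc1cccc(C(C)Sc2nc3c(cnn3C)c(=O)n2-c2ccccc2)c1`: 0.1 h
- compound 3 `CC(Sc1nc2c(cnn2C)c(=O)n1-c1ccccc1)c1ccccc1`: 0.133 h

Compound 3 stands second highest of the three numbers in this assay. Its nearest neighbour is compound 2, a 1.3-fold higher number from compound 2 to compound 3 (0.12 log units; within the scatter), which is within the scatter, so the two cannot be ordered. The furthest is compound 1, a 6.3-fold lower number from compound 1 to compound 3 (0.80 log units; beyond the scatter), a step beyond the scatter; the related step of an 8.3-fold lower number from compound 1 to compound 2 (0.92 log units; beyond the scatter) is of the same kind.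

Compound 4 `CC(Sc1nc2c(cnn2C)c(=O)n1-c1ccccc1)c1cccc(O)c1` differs from compound 3 by hydroxy in place of hydrogen on an aromatic carbon. Going by the values given here, no measured step introduces a hydroxy group. Among the compounds with values here, the only step on the same aromatic carbon is a 1.3-fold higher number from compound 2 to compound 3 (0.12 log units; within the scatter), which stayed within the scatter, so that position appears tolerant on the single pair known. The larger steps concern the swap of the whole aryl group and do not speak to a substituent on the phenyl ring.

Compound 4 is therefore expected to stay close to compound 3, with a 1.1-fold higher number from compound 3 to compound 4 (0.05 log units; within the scatter) as the estimated step, not beyond the scatter. The estimate for compound 4 is 0.15 h, within 0.06 h to 0.4 h.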

Compound 4, half-life: 0.0667 h
For compound 4 the middle estimate is 2.2-fold (0.35 log units) above the measured one, and the stated range covers the measured number.
By their numbers in this assay, from the lowest: compounds 4, 2 and 3 (each within the scatter of the next); then compound 1.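

In this assay, hydroxy in place of hydrogen on the aromatic carbon gives a 2.0-fold lower number from compound 3 to compound 4 (0.30 log units; within the scatter), and hydrogen in place of methyl on the oxygen gives a 1.5-fold lower number from compound 2 to compound 4 (0.18 log units; within the scatter); both steps stay within the scatter, so the phenyl, 3-methoxyphenyl and 3-hydroxyphenyl compounds cannot be ordered. A hydroxy group at this place thus joins methoxy as a change with no readable effect, while replacing pyridin-2-yl with 3-hydroxyphenyl gives a 12-fold lower number from compound 1 to compound 4 (1.10 log units; beyond the scatter), the largest step in the set and one beyond the scatter. No supporting measurement bears on these steps, so the data offer no explanation for them.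

As far as these compounds go, it remains open whether an amine or a carboxylic acid on the same aromatic carbon would also stay within the scatter of compound 3. From the compounds shown here alone, whether a methoxy or hydroxy group on the pyridin-2-yl ring would keep the number of compound 1 is also open.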